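Pyrazole chalcones in a single-concentration cytotoxicity read-out

This account rests on a few compounds, and the source may have more. Where it says the series, first, only, none or still open, it means among the compounds named here.

Measured compounds:
- compound 1, `COc1cc(-c2cc(/C=C/C(=O)c3ccc(N)cc3)[nH]n2)cc(OC)c1OC`: 92%
- compound 2, `COc1ccc(-c2cc(/C=C/C(=O)c3ccc(OC)c(OC)c3)[nH]n2)cc1`: 111%
- compound 3, `COc1cc(C(=O)/C=C/c2cc(-c3cc(OC)c(OC)c(OC)c3)n[nH]2)cc(OC)c1OC`: 103%

In a functional assay on NCI-H522 cells (Homo sapiens) for cytotoxicity, read by sulforhodamine B assay, with a stated time of 48 h, tested at 0.1 uM (on this read-out higher numbers stand for a weaker effect at the one concentration tested and lower numbers for a stronger effect), compound 1 gives 92%, the lowest of the three numbers. Compound 3 lies higher with 103% and compound 2 higher still with 111%, both gaps to compound 1 beyond the scatter, so compound 1 shows the strongest effect of the three in this assay. Among the compounds with values here, no two of the measured compounds differ in only one place, so no single-change step is available to lean on.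

Compound 4, `COc1cc(-c2cc(/C=C/C(=O)c3ccc(F)c(F)c3)[nH]n2)cc(OC)c1OC`, is not yet measured. It differs from compound 1 in one place: 3,4-difluorophenyl in place of 4-aminophenyl on a carbonyl carbon. Within the data shown here, nothing among the measured compounds tells what such a change does to this assay, and all three measured numbers sit close to the no-effect level, so the step from compound 1 to compound 4 is expected to be small, a number 6 percentage points higher from compound 1 to compound 4 (within the scatter), and within the scatter. For compound 4 the estimated result in this assay is 98%, between 85% and 112%.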

Compound 4, a percentage reported as activity, at one concentration (the size of the read-out at that concentration, not a potency): 99%
Beside the measured number, compound 4's estimate is 1 percentage points below it; low and high end bracket the measured number.
By their numbers in this assay, from the lowest: compounds 1, 4, 3 and 2 (each within the scatter of the next, the first and the last beyond it).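

In this assay, within the data shown here, this is the first single-change step available, and it falls on a carbonyl carbon whose other neighbour is a double-bonded chain carbon: a number 7 percentage points higher from compound 1 to compound 4 (within the scatter). Replacing 4-aminophenyl with 3,4-difluorophenyl removes the hydrogen-bond donor and acceptor counted on the leaving group, yet the two compounds are not separated by this read-out, so at this one concentration the 4-aminophenyl group is not shown to be required at this position. No measured evidence at hand bears on why the change leaves the number within the scatter.

On these data alone, whether an unsubstituted phenyl, a 4-hydroxyphenyl or a 4-(dimethylamino)phenyl group at this position would read any differently remains open. Also open, as far as these compounds go, is whether compound 1 and compound 4 would stay together at higher concentrations, where a clearer effect might appear.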